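The source may hold more compounds than are shown below. What is called first, only, known or untested is meant among the compounds shown, and "the series" means these compounds.

The three compounds measured so far in an ADME assay (liver) for metabolic stability, with Liver microsome (Rattus norvegicus) as the target, using microsomes and NADPH, with a stated time of 30 min, tested at 1 uM (a lower number here means slower removal, a higher number faster removal of the compound), are:
compound 1, `COCC#Cc1cc(C(O)(C(F)(F)F)C(F)(F)F)cnc1N1CCN(S(=O)(=O)c2ccc(N)nc2)CC1`, which gives 399 mL.min-1.g-1;
compound 2, `CC(C)(C)n1cc(-c2cc(C(O)(C(F)(F)F)C(F)(F)F)cnc2N2CCN(S(=O)(=O)c3ccc(N)nc3)CC2)cn1`, which gives 459 mL.min-1.g-1;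
compound 3, `Nc1ccc(S(=O)(=O)N2CCN(c3ncc(C(O)(C(F)(F)F)C(F)(F)F)cc3-c3ccccc3O)CC2)cn1`, which gives 125 mL.min-1.g-1.

Compound 2 has the highest number of the three in this assay, though its gap to compound 1, a 1.2-fold higher number from compound 1 to compound 2 (0.06 log units; within the scatter), lies within the scatter; only compound 3 stands clearly apart, by a 3.7-fold lower number from compound 2 to compound 3 (0.56 log units; beyond the scatter). The new compound, compound 4, `Cc1nc2cc(-c3cc(C(O)(C(F)(F)F)C(F)(F)F)cnc3N3CCN(S(=O)(=O)c4ccc(N)nc4)CC3)ccc2o1`, differs from compound 2 in one place: 2-methyl-1,3-benzoxazol-5-yl in place of 1-(tert-butyl)-1H-pyrazol-4-yl on an aromatic carbon. Two kinds of measured step bear on this change. The exchange at the same aromatic carbon from compound 1 to compound 2 moved the number only by a 1.2-fold higher number from compound 1 to compound 2 (0.06 log units; within the scatter), while the exchange to the 2-hydroxyphenyl gave a 3.2-fold lower number from compound 1 to compound 3 (0.50 log units; beyond the scatter) and a 3.7-fold lower number from compound 2 to compound 3 (0.56 log units; beyond the scatter). The group entering in compound 4 has no hydrogen-bond donor, unlike the 2-hydroxyphenyl of compound 3. The donor-free exchange from compound 1 to compound 2 stayed within the scatter and is the closer precedent. Compound 4 is therefore expected to show a step of a 1.4-fold lower number from compound 2 to compound 4 (0.16 log units; within the scatter), within the scatter. For compound 4 the estimate in this assay is 320 mL.min-1.g-1, with a range from 150 mL.min-1.g-1 to 650 mL.min-1.g-1.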

Compound 4, intrinsic clearance in microsomes: 99 mL.min-1.g-1
Beside the measured number, compound 4's estimate is 3.2-fold (0.51 log units) above it; the measured number lies below the stated range.
By their numbers in this assay, from the lowest: compounds 4 and 3 (each within the scatter of the next); then compounds 1 and 2 (each within the scatter of the next).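

In this assay, the aromatic carbon ortho to a large group proves sensitive to the choice among groups with no hydrogen-bond donor: 2-methyl-1,3-benzoxazol-5-yl in place of 1-(tert-butyl)-1H-pyrazol-4-yl gives (a 4.6-fold lower number from compound 2 to compound 4 (0.67 log units; beyond the scatter)), and in place of 3-methoxyprop-1-yn-1-yl it gives (a 4.0-fold lower number from compound 1 to compound 4 (0.61 log units; beyond the scatter)). The earlier compounds shown here showed a step beyond the scatter only with the 2-hydroxyphenyl group, yet the entering group, which has no donor, stands level with it (a 1.3-fold lower number from compound 3 to compound 4 (0.10 log units; within the scatter)), so a donor in this group is not required for a low number. The count of rings does not sort these compounds either, as the single-ring groups of compound 2 and compound 3 lie at opposite ends of the series, and nothing measured here gives a reason for the step.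

The compounds shown leave open whether the low number belongs to the fused six-membered ring, to the 2-methyl group or to the whole 2-methyl-1,3-benzoxazol-5-yl group. A plain phenyl group, an unmethylated benzoxazole or a group bearing a carboxylic acid at this carbon would help separate these possibilities.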